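Removing the chloro substituent from compound 2

This account rests on a few compounds, and the source may have more. Where it says the series, first, only, none or still open, it means among the compounds named here.

Compound 1 `COc1cc2c(Oc3ccc(NC(=O)c4cc(-c5ccccc5)nc5ccccc45)cc3F)ccnc2cc1OCCCN1CCCCC1` gives 1490 nM in a functional assay on U-87MG ATCC cells (Homo sapiens) for cytotoxicity, read by MTT assay, with a stated time of 72 h; a lower number here means a stronger inhibitor, a higher number a weaker inhibitor; compound 2 `COc1cc2c(Oc3ccc(NC(=O)c4cc(-c5cccc(Cl)c5)nc5ccccc45)cc3F)ccnc2cc1OCCCN1CCC(C)CC1` gives 580 nM in this assay.

Compound 2 holds the lower of the two numbers, and compound 1 sits a step beyond the scatter above it; the two differ in two places, so neither place can be credited on its own. Compound 3 `COc1cc2c(Oc3ccc(NC(=O)c4cc(-c5ccccc5)nc5ccccc45)cc3F)ccnc2cc1OCCCN1CCC(C)CC1` carries the change (hydrogen in place of chloro on an aromatic carbon). Within the data shown here, with no single-place step known, the loss of the chloro substituent is expected to weaken compound 3 modestly, as a 1.7-fold higher number from compound 2 to compound 3 (0.24 log units; within the scatter), giving an estimated 1000 nM with a range from 450 nM to 2200 nM.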

Compound 3, half-maximal inhibitory concentration: 920 nM
Estimate against measurement, compound 3: 1.1-fold (0.04 log units) above; low and high end bracket the measured number.
By their numbers in this assay, from the lowest: compounds 2, 3 and 1 (each within the scatter of the next, the first and the last beyond it).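

Compound 3 separates the two changes in this assay: going from 3-chlorophenyl to phenyl gives a 1.6-fold higher number from compound 2 to compound 3 (0.20 log units; within the scatter), and methyl in place of hydrogen on the saturated ring carbon gives a 1.6-fold lower number from compound 1 to compound 3 (0.21 log units; within the scatter). Neither single change, taken alone, moves the number beyond the scatter. No measured evidence here bears on this result.

Still open, going by these compounds, is how a methoxy group, a nitrile or an amine on that aromatic carbon would read. Also open, on these data alone, is how a hydroxyl group or a longer chain would read on the saturated ring carbon.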